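A few compounds are considered here, and "the series" means these few. Any claim that something is new, unique, unknown or untested is made for them only; others in the source may bear on it.

The series shares a single core. Compound 1 `O=C(N/N=C/c1cccc(F)c1)c1cnccn1` is assessed in an ADME assay on J774 cells (Mus musculus) for cytotoxicity, read by MTT assay, with a stated time of 48 h, tested at 100 ug/mL (a higher number here means a weaker effect of the compound at the concentration tested, a lower number a stronger effect), and gives 46%. Compound 2 `CCOc1cccc(/C=N/NC(=O)c2cnccn2)c1` is assessed in this assay and gives 71%. Among the measured compounds shown here, the only measured step, ethoxy in place of fluoro on an aromatic carbon, is a number 25 percentage points higher from compound 1 to compound 2 (beyond the scatter). Among the two compounds with numbers, compound 2 therefore stands highest, with compound 1 the nearest and lower by a margin beyond the scatter.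

Compound 3 `O=C(N/N=C/c1cccc([N+](=O)[O-])c1)c1cnccn1` is not yet measured. Its difference from compound 2 is nitro in place of ethoxy on an aromatic carbon. For the measured compounds named here, no measured step involves a nitro group. Going by the values given here, the one step at hand, a number 25 percentage points higher from compound 1 to compound 2 (beyond the scatter), shows that exchanging a group at this place on the ring can shift the number by a modest amount beyond the scatter; that step ran upward on introducing ethoxy, and compound 3 removes that same ethoxy, so a downward step in this assay is the more likely direction, though its size is uncertain and a step beyond the scatter is not assured. For compound 3 the step from compound 2 is estimated as a number 16 percentage points lower from compound 2 to compound 3 (beyond the scatter). Compound 3 is expected to give about 55%, between 35% and 75%.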

Compound 3, a percentage reported as activity, at one concentration (the size of the read-out at that concentration, not a potency): 85%
Estimate against measurement, compound 3: 30 percentage points below, and the stated range ends below it.
By their numbers in this assay, from the lowest: compound 1; then compound 2; then compound 3.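

Replacing ethoxy with nitro at this place on the ring, on an aromatic carbon meta to a large group, gives a number 14 percentage points higher from compound 2 to compound 3 (beyond the scatter) in this assay, so a high number here does not depend on the ethoxy group. Among the compounds shown here, the two groups count the same 3 heavy atoms and neither carries a ring or a net charge, yet their numbers still differ beyond the scatter, so that heavy-atom count alone does not fix the read-out across this pair; the change from fluoro to nitro gives a number 39 percentage points higher from compound 1 to compound 3 (beyond the scatter), the widest step so far and the only one rated large. Nothing available here bears on why the read-out follows this order among fluoro, ethoxy and nitro.

On these data alone, with only these three groups at one place on the ring, it stays open how an amine, a carboxylic acid or a longer alkoxy chain would read at the same carbon. As far as these compounds go, it is equally open whether the same order of fluoro, ethoxy and nitro would hold with these groups at another carbon of the ring or with a change elsewhere on the shared core.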